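Swapping an amide side chain for a carboxylic acid

The source may hold more compounds than are shown below. What is called first, only, known or untested is meant among the compounds shown, and "the series" means these compounds.

Of the compounds shown here, three that share a core have been measured in a physicochemical assay for lipophilicity, read by HPLC, at pH 7.5; a higher number here means a more lipophilic compound, a lower number a more polar compound. Compound 1, `CCOc1ccccc1-c1ccc(-c2nc3cnccc3c(NC(COC)C(N)=O)c2C#N)cc1`, gives 2.8. Compound 2, `CC[C@@H](Nc1c(C#N)c(-c2ccc(-c3ccccc3NC)cc2)nc2cnccc12)C(N)=O`, gives 2.5, a number that sits within the usual scatter of the value for compound 1, so the two cannot be told apart. Compound 3, `CC(C)(CC(N)=O)c1c(C#N)c(-c2ccc(Br)cc2)nc2cnccc12`, gives 2.1, which lies lower than compound 1 by more than the scatter. Compound 1 therefore stands at the upper end of this small set, with compound 2 indistinguishable from it and compound 3 clearly below it.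

Compound 4, `CCOc1ccccc1-c1ccc(-c2nc3cnccc3c(N[C@H](CC)C(=O)O)c2C#N)cc1`, has not yet been measured in this assay. It differs from compound 1 in one place: 1-carboxypropyl in place of 1-carbamoyl-2-methoxyethyl on a nitrogen on an aromatic ring. For the measured compounds named here, no measured pair shows this exact change, so the expectation rests on the structures alone. For compound 4 a sizeable fall is expected, a number 1.80 log units lower from compound 1 to compound 4 (beyond the scatter), well beyond the scatter. Compound 4 is estimated to give 1 in this assay, within a range of 0.2 to 1.8.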

Compound 4, distribution coefficient: 2.1
Beside the measured number, compound 4's estimate is 1.10 log units below it, outside the stated range (above it).
By their numbers in this assay, from the lowest: compounds 3 and 4 (each within the scatter of the next); then compounds 2 and 1 (each within the scatter of the next).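

For the compounds shown here, this is the only step in the set that changes the group on the nitrogen on an aromatic ring while the rest of the molecule stays the same, and in this assay it reads a number 0.70 log units lower from compound 1 to compound 4 (beyond the scatter) and is modest in size. It shows that the number responds to the group at this position, even though the leaving and entering groups have similar heavy-atom counts. No measurement shown gives a cause for the size of this step.

The change alters two things at once, as the amide becomes a carboxylic acid and the methoxy group leaves the chain, so the compounds shown cannot divide the step between them. A 1-carbamoylpropyl or 1-carboxy-2-methoxyethyl group on the same nitrogen of compound 1 would separate the two, and an amine there would add a further type of group.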